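The compounds below may be only part of what the source reports. "The series", "measured", "known", "first", "only" and "open" are said of these compounds alone.

Measured in a functional assay on HepG2 cells (Homo sapiens) for cytotoxicity, read by MTT assay, with a stated time of 24 h; a lower number here means a stronger inhibitor, a higher number a weaker inhibitor:

Compound 1 `COc1cc(/C=C2\CN(C)C/C(=C\c3ccc(F)cc3)C2=O)cc(OC)c1`: 6140 nM
Compound 2 `COc1cc(/C=C2\CN(C)C/C(=C\c3ccc(Cl)cc3)C2=O)cc(OC)c1`: 5950 nM
Compound 3 `CN1C/C(=C\c2ccc(F)cc2)C(=O)/C(=C/c2cccc([N+](=O)[O-])c2)C1`: 9340 nM

Compound 1 and compound 2 share a core and differ in one place: chloro in place of fluoro on an aromatic carbon. That change made a 1.0-fold lower number from compound 1 to compound 2 (0.01 log units; within the scatter). Compound 3 has a different core; the difference between the two cores is not broken down here, and the values of compound 1 and compound 3 lie within the usual scatter of each other.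

Compound 4 `CN1C/C(=C\c2ccc(Cl)cc2)C(=O)/C(=C/c2cccc([N+](=O)[O-])c2)C1` has not yet been measured. It relates to compound 3 exactly as compound 2 relates to compound 1: chloro in place of fluoro on an aromatic carbon. The place of the change is the same in both pairs.

The step from compound 3 to compound 4 is expected to be a 1.0-fold lower number from compound 3 to compound 4 (0.02 log units; within the scatter) in this assay, which rests on the earlier step of a 1.0-fold lower number from compound 1 to compound 2 (0.01 log units; within the scatter). Compound 4 is therefore estimated at 9000 nM, with a likely range from 4500 nM to 18000 nM.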

Compound 4, half-maximal inhibitory concentration: 8210 nM
For compound 4 the middle estimate is 1.1-fold (0.04 log units) above the measured one, within the range that was stated.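

In this assay, replacing 4-fluorophenyl with 4-chlorophenyl gave a 1.1-fold lower number from compound 3 to compound 4 (0.06 log units; within the scatter). Set beside the earlier step, the change looks the same on the two cores: the same change on two cores in this assay, a 1.0-fold lower number (0.01 log units; within the scatter) from compound 1 to compound 2 and a 1.1-fold lower number (0.06 log units; within the scatter) from compound 3 to compound 4, 1.1-fold (0.04 log units) apart, within the scatter of two such steps

So on both cores shown, swapping fluoro for chloro left the number within the scatter, but this does not show that a real effect of the change carries from one core to another, as neither step is large enough to be read as an effect. The compounds shown leave open whether an amine or a carboxylic acid in place of the chloro would shift the number beyond the scatter, and whether such a shift would then match on both cores.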